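The compounds below may be only part of what the source reports. "The series", "measured", "known", "first", "only" and "open" are said of these compounds alone.

Measured so far:
compound 1 `CCOC(=O)c1cccc(-c2n[nH]c3ccccc23)c1`: in a functional assay on cells (Platelet, Homo sapiens) for inhibition (a lower number here means a stronger inhibitor, a higher number a weaker inhibitor), compound 1 gives > 10000 nM, a limit of the assay and not a number.
compound 2 `CCOC(=O)c1ccc(-c2nn(C)c3ccccc23)cc1`: in this assay compound 2 gives > 10000 nM, likewise a limit.
compound 3 `CCOC(=O)c1ccc(-c2nn(Cc3ccccc3F)c3ccccc23)cc1`: in this assay compound 3 gives > 10000 nM, again a limit.

Within the data shown here, the one step between measured compounds that differ in a single place, a step that the two limits leave unreadable from compound 2 to compound 3, cannot be sized. Among the measured compounds shown here, compound 3 therefore stands at the limit, and the two further values shown are limits as well; no compound in the set has a readable number.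

Compound 4 `CCOC(=O)c1ccc(-c2nn(Cc3ccc(OC)cc3)c3ccccc23)cc1` differs from compound 3 by 4-methoxyphenyl in place of 2-fluorophenyl on a saturated chain carbon bound to an aromatic nitrogen. For the measured compounds named here, only the step from compound 2 to compound 3 bears on this change, and it gives no size and no direction. Because (the limit of > 10000 nM in this assay, at which 3 of the 3 values shown sit), compound 4 is expected to remain at the limit too. The step expected is a step that the limit leaves unreadable from compound 3 to compound 4. Compound 3 has no number from which such a step could be read. For compound 4 the estimate is 20000 nM, with a range from 5000 nM to 100000 nM, expected to be reported as a limit.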

Compound 4, half-maximal inhibitory concentration: > 10000 nM
Compound 4 ended at the assay's limit; the forecaster's own chance of this, stated with the estimate: 85%; the middle value is on the limit's open side.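

Compound 4 also stands at a limit of the assay, so the steps to compound 4 from compound 2 and compound 3 cannot be read: the limit of > 10000 nM in this assay, at which 4 of the 4 values shown sit. The compounds shown leave open whether 2-fluorobenzyl to 4-methoxybenzyl changes inhibition at all, and what would give a readable number.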